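The source may report more compounds than this note shows. Statements on the series, on what has been measured and on what is new or still open speak of the compounds shown alone.

Measured in a functional assay on PC-3 cells (Homo sapiens) for cytotoxicity, read by MTT assay, with a stated time of 72 h; a lower number here means a stronger inhibitor, a higher number a weaker inhibitor:
- compound 1 `COc1ccc(/C=N/NC(=O)Nc2cc3c(Nc4ccc(F)c(Cl)c4)ncnc3cc2O[C@H]2CCOC2)cc1` gives 34100 nM
- compound 2 `COc1cc2ncnc(Nc3ccc(F)c(Cl)c3)c2cc1NC(=O)N/N=C/c1cccc(Br)c1` gives "not active" (no number reported)
- compound 3 `COc1ccc(/C=N/NC(=O)Nc2cc3c(Nc4ccc(F)c(Cl)c4)ncnc3cc2OC)cc1` gives 16500 nM

Going by the values given here, compound 3 holds the lower of the only two numbers, while compound 2 offers no number for comparison. Compound 4 `COc1cc2ncnc(Nc3ccc(F)c(Cl)c3)c2cc1NC(=O)N/N=C/c1ccc(O)cc1` differs from compound 3 by one change, hydrogen in place of methyl on an oxygen on an aromatic ring, which turns 4-methoxyphenyl into 4-hydroxyphenyl (hydrogen in place of methyl on an oxygen on an aromatic ring).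

Among the compounds with values here, only one measured step offers any guide. This step, a 2.1-fold lower number from compound 1 to compound 3 (0.32 log units; beyond the scatter), is modest and also changes a group on an oxygen on an aromatic ring, though not the oxygen at issue here. Within the data shown here, no measured pair isolates the change from methoxy to hydroxy, so the guide is a loose one. In this assay a small change is therefore expected, with no firm direction. The step expected here is a 1.2-fold higher number from compound 3 to compound 4 (0.08 log units; within the scatter) and it would probably stay within the scatter. For compound 4 the estimated value is 20000 nM with an expected range from 7000 nM to 50000 nM as a rough guide.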

Compound 4, half-maximal inhibitory concentration: 16600 nM
For compound 4 the middle estimate is 1.2-fold (0.08 log units) above the measured one, and the stated range covers the measured number.
By their numbers in this assay, from the lowest: compounds 3 and 4 (each within the scatter of the next); then compound 1.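

In this assay, replacing the methyl on this oxygen with hydrogen, which turns 4-methoxyphenyl into 4-hydroxyphenyl, gives a 1.0-fold higher number from compound 3 to compound 4 (0.00 log units; within the scatter). The earlier step concerned a different oxygen, so this pair is the only direct test of this group, and it shows that the methyl can be removed with no difference beyond the usual scatter of the assay. Nothing measured here accounts for the two compounds reading alike.

On these data alone, only hydroxy and methoxy have been compared on this oxygen, so it remains open whether a longer chain, such as butyl, would also leave the number unchanged. As far as these compounds go, it is equally open whether replacing this oxygen group with an amine or a carboxylic acid would move the number beyond the scatter.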